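The source may report more compounds than this note shows. Statements on the series, on what has been measured and on what is new or still open speak of the compounds shown alone.

Measured so far in a functional assay on B16 cells (Mus musculus) for inhibition; a higher number here means a weaker inhibitor, a lower number a stronger inhibitor:
- compound 1 `O=C(CCc1ccc(O)c(O)c1)O[C@@H]1C[C@](O)(C(=O)O)C[C@@H](O)[C@H]1O`: > 40000 nM (a limit, not a number)
- compound 2 `O=C(/C=C/c1ccc(O)c(O)c1)NC1CCCC1`: 30000 nM
- compound 3 `O=C(/C=C/c1ccc(O)c(O)c1)Nc1ccc(C(F)(F)F)cc1`: 1400 nM

Compound 3 has the lower of the two exact numbers, and its gap to compound 2 lies beyond the scatter. Compound 4 `O=C(/C=C/c1ccc(O)c(O)c1)Nc1ccc([N+](=O)[O-])cc1` has nitro in place of trifluoromethyl on an aromatic carbon, para to a large group: nitro in place of trifluoromethyl on an aromatic carbon. Among the compounds with values here, no measured step shows this kind of exchange, so the expectation rests on compound 3 at 1400 nM. A small shift in this assay toward a somewhat higher number is expected, possibly within the scatter. The expected change is a 1.4-fold higher number from compound 3 to compound 4 (0.15 log units; within the scatter). For compound 4 the estimated value is 2000 nM, with an expected range from 600 nM to 7000 nM.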

Compound 4, half-maximal inhibitory concentration: 1400 nM
Compound 4: the middle estimate sits 1.4-fold (0.15 log units) above what was measured, and the stated range covers the measured number.
By their numbers in this assay, from the lowest: compounds 3 and 4 (each within the scatter of the next); then compound 2. At a limit, above all of these: compound 1.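

In this assay, the exchange on this aromatic carbon, para to a large group, gives no change at the digits printed from compound 3 to compound 4 (within the scatter). Until now the position had been seen with trifluoromethyl alone; with nitro, which brings hydrogen-bond acceptors that trifluoromethyl lacks, this assay does not tell the two groups apart. The compounds shown offer no measured reason for this. On these data alone, whether an amine, a carboxylic acid or a methoxy group on the same carbon would also fall within the scatter of these two stays open. Two groups alone do not show how far this tolerance extends.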